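Notes on the step from compound 2 to compound 4

This account rests on a few compounds, and the source may have more. Where it says the series, first, only, none or still open, it means among the compounds named here.

- compound 1 `c1ccc2c(c1)CN[C@@H](CN(CC[C@@H]1CCCNC1)[C@H]1CCCc3cccnc31)C2`: 28%
- compound 2 `c1ccc2c(c1)CN[C@@H](CN(CCC1CCNCC1)[C@H]1CCCc3cccnc31)C2`: 17%
- compound 3 `c1cnc2c(c1)CN[C@H](CN(CCCN1CCNCC1)[C@H]1CCCc3cccnc31)C2`: 87%

In an ADME assay on microsomes from liver (Rattus norvegicus) for metabolic stability, read by LC-MS, with a stated time of 10 min, tested at 0.5 uM (on this read-out higher numbers stand for a more stable compound and lower numbers for a less stable compound), compound 2 gives 17%, the lowest of the three numbers, and the gaps to both other compounds lie beyond the scatter. The next compound to be measured is compound 4 `NC(=O)N1CCN(CCCN(C[C@H]2Cc3ccccc3CN2)[C@H]2CCCc3cccnc32)CC1`, which differs from compound 2 as follows: (4-carbamoylpiperazin-1-yl)methyl in place of piperidin-4-yl on a saturated chain carbon, two bonds along the chain from an amine nitrogen. The group is exchanged on a saturated chain carbon, two bonds along the chain from an amine nitrogen.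

Among the compounds with values here, only one measured step bears on this directly: a number 11 percentage points lower from compound 1 to compound 2 (beyond the scatter). That step is modest and swaps piperidin-3-yl for piperidin-4-yl, a far smaller change, so it sets no size for this one. The piperazine ring also occurs in compound 3 at 87%, but without the carbamoyl group and on a different core, so this is only a loose guide. A large upward step is expected, a number 43 percentage points higher from compound 2 to compound 4 (beyond the scatter). For compound 4 the estimated value is 60%, with an expected range of 35% to 85%.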

Compound 4, percent of the compound remaining: 4%
The estimate for compound 4 lay 56 percentage points above the measured number; the measured number lies below the stated range.
By their numbers in this assay, from the lowest: compound 4; then compound 2; then compound 1; then compound 3.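

In this assay, placing (4-carbamoylpiperazin-1-yl)methyl on this saturated chain carbon gives a number 13 percentage points lower from compound 2 to compound 4 (beyond the scatter) and a number 24 percentage points lower from compound 1 to compound 4 (beyond the scatter), so on the shared core this larger group falls below both piperidine-bearing compounds. The piperazine ring therefore does not carry a high number with it to this position when it bears the carbamoyl group, and compound 3, which differs in more than one place, cannot settle the matter. No evidence on the cause of the fall is available.

The compounds shown do not separate the contribution of the carbamoyl group from that of the piperazine ring, since the two enter together. An unsubstituted piperazin-1-ylmethyl group, an acetyl group in place of the carbamoyl or a morpholine ring on the same core would address that question.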